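Compound 4, a difluorophenyl variant of compound 3

A few compounds are considered here, and "the series" means these few. Any claim that something is new, unique, unknown or untested is made for them only; others in the source may bear on it.

Three compounds have numbers in a functional assay on NCI-H1975 cells (Homo sapiens) for inhibition, read by CellTiter-Glo, with a stated time of 72 h; on this read-out lower numbers stand for stronger inhibition of growth and higher numbers for weaker inhibition of growth. Compound 1 `C=CC(=O)Nc1cc(Nc2ncc(C)c(Nc3ccccc3S(=O)(=O)C(C)C)n2)c(OC)cc1N1CCC(N2CCN(C)CC2)CC1` gives 27 nM, compound 2 `C=CC(=O)Nc1cc(Nc2nccc(Nc3ccccc3S(=O)(=O)C(C)C)n2)c(OC)cc1N1CCN(CC)CC1` gives 190 nM, and compound 3 `C=CC(=O)Nc1cc(Nc2ncc(Cl)c(Nc3cccc(C(F)(F)F)c3)n2)c(OC)cc1N1CCN(C)CC1` gives 260 nM. Compound 3 holds the highest of the three numbers; it sits within the scatter of compound 2 and beyond the scatter above compound 1. Compound 4 `C=CC(=O)Nc1cc(Nc2ncc(Cl)c(Nc3c(F)cccc3F)n2)c(OC)cc1N1CCN(C)CC1` differs from compound 3 by 2,6-difluorophenyl in place of 3-(trifluoromethyl)phenyl on a nitrogen on an aromatic ring. For the measured compounds named here, no measured pair shows this change, so the data give no direction or size for it. The step is expected to be a 1.2-fold higher number from compound 3 to compound 4 (0.06 log units; within the scatter), none beyond the scatter. Compound 4 is therefore estimated to give 300 nM in this assay, within a range from 80 nM to 1200 nM.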

Compound 4, concentration for 50% growth inhibition: 130 nM
For compound 4 the middle estimate is 2.3-fold (0.36 log units) above the measured one, within the range that was stated.
By their numbers in this assay, from the lowest: compound 1; then compounds 4, 2 and 3 (each within the scatter of the next).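

In this assay the first step read at this position is a 2.0-fold lower number from compound 3 to compound 4 (0.30 log units; within the scatter) for 2,6-difluorophenyl in place of 3-(trifluoromethyl)phenyl on a nitrogen on an aromatic ring. The number therefore does not separate these two groups, although the one entering has fewer heavy atoms. Nothing available here explains this result. Going by these compounds, it remains open whether a phenyl ring carrying an amine or a carboxylic acid at this place would give a step beyond the scatter. On these data alone, whether the same exchange behaves alike on a core without the chlorine is also open.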